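The source may hold more compounds than are shown below. What is called first, only, known or untested is meant among the compounds shown, and "the series" means these compounds.

Two compounds share one core and differ only in the five-membered ring attached to it. Compound 1 `c1csc(-c2ccccc2OCC2=NCCN2)c1` carries thiophen-2-yl; in a functional assay with Alpha-1D adrenergic receptor (Homo sapiens) as the target, read by calcium flux (a higher number here means a larger maximal response, a lower number a smaller maximal response), compound 1 gives 93%. Compound 2 `c1ccc(-c2ccsc2)c(OCC2=NCCN2)c1` carries thiophen-3-yl instead, and in this assay compound 2 gives 120%. Going by the values given here, the only measured step, a number 27 percentage points higher from compound 1 to compound 2 (beyond the scatter), shows that moving the sulfur within the attached ring changed the maximal response by a modest amount beyond the scatter. On the two numbers shown, compound 2 stands highest, and compound 1 is the nearest.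

Compound 3 `c1ccc(-c2ccns2)c(OCC2=NCCN2)c1` is not yet measured. It differs from compound 2 in one place: 1,2-thiazol-5-yl in place of thiophen-3-yl on an aromatic carbon. Among the compounds with values here, no measured step covers an exchange of a ring carbon for a ring nitrogen, so the only guide is the size of the measured step, which was modest. For compound 3 in this assay a change of similar or smaller size is expected, and the direction is uncertain, so the estimate is set a little below compound 2, a step of a number 15 percentage points lower from compound 2 to compound 3 (beyond the scatter). The expected value for compound 3 is therefore 105%, within the range 75% to 135%.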

Compound 3, largest response reached (reported as maximum), in percent of the reference or control that the assay uses: 82%
Beside the measured number, compound 3's estimate is 23 percentage points above it; low and high end bracket the measured number.
By their numbers in this assay, from the lowest: compound 3; then compound 1; then compound 2.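

In this assay, 1,2-thiazol-5-yl in place of thiophen-3-yl gives a number 38 percentage points lower from compound 2 to compound 3 (beyond the scatter), a large step, whereas moving the sulfur within the thiophene ring gave only a modest one. Compared with the other thiophene, the same ring gives a number 11 percentage points lower from compound 1 to compound 3 (beyond the scatter), so compound 3 lies below both thiophene compounds and the position on the aromatic carbon ortho to a group of 7 heavy atoms proves sensitive to the make-up of the five-membered ring, not only to where the sulfur sits. The swap adds a ring nitrogen and a second hydrogen-bond acceptor to the group, but nothing available accounts for the difference in maximal response between these rings.

The compounds shown leave open whether the ring nitrogen must sit where it does in 1,2-thiazol-5-yl, which 1,3-thiazol-5-yl or 1,3-thiazol-2-yl would help to test, and whether sulfur itself matters, which furan-3-yl would address. They also leave open how a six-membered ring such as pyridin-3-yl, or a group without a ring such as an amine or a carboxylic acid, would behave at this position.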